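1H-Imidazol-1-yl in place of pyrrolidin-1-yl: compound 4

The source may hold more compounds than are shown below. What is called first, only, known or untested is meant among the compounds shown, and "the series" means these compounds.

Compound 1, `Cn1c(CSc2ccccc2)nc2c(CN3CCCC3)c(O)ccc21`: 227000 nM
Compound 2, `COc1cccc(SCc2nc3c(Cn4ccnc4C)c(O)ccc3n2C)c1`: 103000 nM
Compound 3, `Cn1c(CSc2ccc(F)cc2)nc2c(CN3CCCC3)c(O)ccc21`: 74800 nM

Among the three compounds measured in an ADME assay on HepG2 2.2.15 cells (Homo sapiens) for cytotoxicity, with a stated time of 9 days (on this read-out higher numbers stand for lower toxicity in this test and lower numbers for higher toxicity in this test), compound 1 stands highest. Compound 2 is the nearest to it and compound 3 the furthest, and both gaps lie beyond the scatter.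

Compound 4, `Cn1c(CSc2ccccc2)nc2c(Cn3ccnc3)c(O)ccc21`, has not yet been measured. It differs from compound 1 in one place: 1H-imidazol-1-yl in place of pyrrolidin-1-yl on a saturated chain carbon bound to an aromatic carbon.

Among the measured compounds shown here, only one measured step is available, a 3.0-fold lower number from compound 1 to compound 3 (0.48 log units; beyond the scatter), and it concerns a change on the aromatic carbon of the thioether ring rather than the group on the saturated chain carbon; it therefore bears on the present change only in showing that single modifications of the shared core can move this read-out beyond the scatter. For the measured compounds named here, no measured pair isolates the swap of pyrrolidin-1-yl for 1H-imidazol-1-yl. Compound 2, which carries a different group at that position together with a second change elsewhere, gives a lower number than compound 1, but the two changes cannot be separated.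

On this basis a modest lowering is expected. Compound 4 is estimated at 150000 nM, with a range from 60000 nM to 350000 nM. This corresponds to an expected step of a 1.5-fold lower number from compound 1 to compound 4 (0.18 log units; within the scatter).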

Compound 4, half-maximal cytotoxic concentration: 76300 nM
Compound 4: the middle estimate sits 2.0-fold (0.29 log units) above what was measured, within the range that was stated.
By their numbers in this assay, from the lowest: compounds 3, 4 and 2 (each within the scatter of the next); then compound 1.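

In this assay, among the compounds shown here, the replacement of pyrrolidin-1-yl by 1H-imidazol-1-yl on a saturated chain carbon bound to an aromatic carbon gives a 3.0-fold lower number from compound 1 to compound 4 (0.47 log units; beyond the scatter), the first reading in which a change at this position stands alone. Until now, the only single-place step was on the aromatic ring of the thioether, a 3.0-fold lower number from compound 1 to compound 3 (0.48 log units; beyond the scatter), so the group on the saturated chain carbon is now shown to move this read-out as well. The step arises although the two groups have the same count of heavy atoms and neither carries a net charge, while the entering ring is aromatic and holds one more nitrogen. Nothing available explains this step.

The compounds shown leave open how an open-chain dimethylamino group or a morpholin-4-yl group would read on the same saturated chain carbon, and so whether the step belongs to the imidazole ring in particular or to any departure from pyrrolidin-1-yl. They also leave open whether the fluoro change and the 1H-imidazol-1-yl change would add up if combined in one compound, and how much of the number of compound 2 comes from the methyl group on its imidazole ring or from its methoxy group.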